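The compounds below may be only part of what the source reports. "The series", "measured", "known", "first", "only" and "open" are said of these compounds alone.

Measured in a functional assay on MDA-MB-231 cells (Homo sapiens) for antiproliferative activity, read by luminescence, with a stated time of 72 h; on this read-out lower numbers stand for stronger inhibition and higher numbers for weaker inhibition:
- compound 1 `Oc1ccc(Cn2cnc(F)c2)c2cccnc12`: 34300 nM
- compound 2 `Oc1ccc(Cn2cncn2)c2cccnc12`: 6700 nM

Compound 2 holds the lower of the two numbers, and its gap to compound 1 lies beyond the scatter. Compound 3 `Oc1ccc(Cn2cccn2)c2cccnc12` keeps the shared core and carries 1H-pyrazol-1-yl in place of 1H-1,2,4-triazol-1-yl on a saturated chain carbon bound to an aromatic carbon. Going by the values given here, only one measured step bears on this change, a modest one at that same place: a 5.1-fold lower number from compound 1 to compound 2 (0.71 log units; beyond the scatter). Like compound 1, compound 3 has a five-membered aromatic ring with 2 hetero atoms, but it has no fluorine. A smaller move towards a higher number is therefore expected, possibly none beyond the scatter. The expected step is a 1.5-fold higher number from compound 2 to compound 3 (0.17 log units; within the scatter). For compound 3 the estimated value is 10000 nM, with an expected range of 3500 nM to 30000 nM.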

Compound 3, half-maximal inhibitory concentration: 3600 nM
Compound 3: middle estimate off by 2.8-fold (0.44 log units), on the high side, and the stated range covers the measured number.
By their numbers in this assay, from the lowest: compounds 3 and 2 (each within the scatter of the next); then compound 1.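

In this assay, 1H-pyrazol-1-yl in place of 1H-1,2,4-triazol-1-yl on the saturated chain carbon gives a 1.9-fold lower number from compound 2 to compound 3 (0.27 log units; within the scatter), so this position accepts either group without a change that can be told from the scatter. Compound 3 shares with compound 1 a five-membered aromatic ring with 2 hetero atoms, yet a 9.5-fold lower number from compound 1 to compound 3 (0.98 log units; beyond the scatter) appears with that count unchanged, which shows that the number of ring hetero atoms alone does not set the value here. No measurement shown offers a reason for these differences.

The compounds shown leave open whether the gap to compound 1 goes with its fluorine or with the arrangement of atoms in its ring, since the two differ together. They also leave open how this position would respond to a phenyl ring or an open-chain amine.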